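Bromine on the indole ring of a growth inhibitor

The source may report more compounds than this note shows. Statements on the series, on what has been measured and on what is new or still open speak of the compounds shown alone.

Measured compounds:
Compound 1, `COC(=O)[C@@]1(C)CC[C@@H]2C3=C1CC[C@@H](C)[C@]3(C)C[C@@H]1c3cc(Cl)ccc3N[C@H]21`: 28000 nM
Compound 2, `COC(=O)[C@@]1(C)CC[C@@H]2C3=C1CC[C@@H](C)[C@]3(C)C[C@@H]1c3cc(F)ccc3N[C@H]21`: 18000 nM
Compound 3, `COC(=O)[C@@]1(C)CC[C@@H]2C3=C1CC[C@@H](C)[C@]3(C)Cc1c2[nH]c2ccccc12`: 3500 nM

In a functional assay on HBL-100 cells (Homo sapiens) for inhibition, read by sulforhodamine B assay, with a stated time of 48 h (a lower number here means a stronger inhibitor of growth, a higher number a weaker inhibitor of growth), compound 3 gives the lowest of the three numbers, clearly lower than compound 2 and further still from compound 1, so among these three it is the strongest inhibitor of growth. Compound 4, `COC(=O)[C@@]1(C)CC[C@@H]2C3=C1CC[C@@H](C)[C@]3(C)Cc1c2[nH]c2ccc(Br)cc12`, differs from compound 3 by a single change: bromo in place of hydrogen on an aromatic carbon. The ring that receives the bromine sits on the far side of the shared core from the ester and is otherwise unchanged.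

Within the data shown here, only one measured step says anything about a halogen on that aromatic ring: a 1.6-fold lower number from compound 1 to compound 2 (0.19 log units; within the scatter). That step exchanges one halogen for another rather than adding one to a bare ring, and it happens in a core that differs from the core of compound 3, so it is an imperfect guide. It does show that a change of halogen at an aromatic carbon of this kind left the number essentially where it was. On that basis the expected step in this assay from compound 3 to compound 4 is small, no change at the digits printed from compound 3 to compound 4 (within the scatter), with no direction settled. Compound 4 is therefore estimated at 3500 nM, within a range of 1200 nM to 10000 nM.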

Compound 4, concentration for 50% growth inhibition: 16000 nM
Estimate against measurement, compound 4: 4.6-fold (0.66 log units) below; measured number outside the range, above it.
By their numbers in this assay, from the lowest: compound 3; then compounds 4, 2 and 1 (each within the scatter of the next).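

In this assay, adding a bromo group to the previously bare aromatic ring gives a 4.6-fold higher number from compound 3 to compound 4 (0.66 log units; beyond the scatter), a loss of growth inhibition that lies beyond the usual scatter. This shows that the carbon meta to a fused ring and para to a fused ring is not indifferent to substitution, since even one heavy atom placed there moves the number clearly. The earlier halogen step, a 1.6-fold lower number from compound 1 to compound 2 (0.19 log units; within the scatter), could not show this, since it exchanged one halogen for another on a different core and did not add a group to an unsubstituted ring; no measurement at hand explains why the bromo group has this effect.

The compounds shown cover only one group at this carbon of the indole-bearing core, so it remains open whether a methoxy group, an amine or a carboxylic acid there would cost as much, or whether any of them would cost nothing at all. On these data alone, it also remains open whether a bromo group on another carbon of the same ring would give a similar step.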